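A few compounds are considered here, and "the series" means these few. Any claim that something is new, unique, unknown or untested is made for them only; others in the source may bear on it.

Among the compounds with values here, compound 1 `CCCCCCCCNc1ccc(-c2ccccc2)cc1` and compound 2 `CCCCCCCCCNc1ccccc1-c1ccccc1` are the two compounds with numbers so far. In an in vitro assay on BTI-TN-5B1-4 cells for inhibition of sterol O-acyltransferase 2 (Homo sapiens), tested at 50 uM (on this read-out higher numbers stand for more inhibition at the one concentration tested (going by the name of the read-out) and lower numbers for less inhibition), compound 1 gives 6%. Compound 2, in the same assay, gives -1%. These two numbers lie within the usual scatter of each other, so neither compound can be set above the other on these data; both show little inhibition at the single concentration tested. Compound 3 `CCCCCCCCCNc1ccc(-c2ccccc2)cc1` shares the core of compound 1 and differs from it by methyl in place of hydrogen on a saturated chain carbon, eight bonds along the chain from a nitrogen on an aromatic ring; the same difference, cut one bond further out, reads methyl to ethyl, ethyl to propyl, propyl to butyl, a lengthening of the saturated chain by one carbon. Within the data shown here, no step between measured compounds is known, so the size of this change cannot be read from a pair already in hand. Because compound 2 gives -1% and compound 1 gives 6%, the step from compound 1 to compound 3 is expected to be small, a number 1 percentage points lower from compound 1 to compound 3 (within the scatter), not beyond the scatter in either direction. Compound 3 is therefore estimated at 5%, within a range of -8% to 18%.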

Compound 3, a percentage reported as inhibition, at one concentration (the size of the read-out at that concentration, not a potency): 18%
For compound 3 the middle estimate is 13 percentage points below the measured one; the range from low to high includes it.
By their numbers in this assay, from the lowest: compounds 2 and 1 (each within the scatter of the next); then compound 3.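

In this assay, within the data shown here, adding one carbon to the saturated chain gives the first step beyond the scatter: with methyl in place of hydrogen on a saturated chain carbon, eight bonds along the chain from a nitrogen on an aromatic ring, the read-out moves by a number 12 percentage points higher from compound 1 to compound 3 (beyond the scatter). Among these compounds, this shows that the outer end of the chain is not indifferent to a change as small as one carbon, which the two earlier compounds, with no step between them, could not show, although this rests on a single pair read at one concentration. Nothing in the data accounts for the change, so the step stands without an explanation.

On these data alone, one step gives no trend, so it remains open whether a longer chain, such as decyl, would go on raising the inhibition or whether the effect would level off or reverse. As far as these compounds go, it is also open how a carboxylic acid or an amine at the end of the chain would read at this position, and whether compound 3, at 18%, would show a stronger or weaker effect at other concentrations.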